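Swapping the aryl cap on a glutamate receptor modulator

The compounds below may be only part of what the source reports. "The series", "measured", "known", "first", "only" and "open" are said of these compounds alone.

Of the compounds shown here, two have been tested in an assay on HEK293 cells for positive allosteric modulation of metabotropic glutamate receptor 2 (Rattus norvegicus), read by thallium flux, with a stated time of 2.5 min; on this read-out higher numbers stand for larger maximal responses and lower numbers for smaller maximal responses. Compound 1, `COC(=O)c1ccc(OCCCCOc2ccc(C(=O)CC(C)C)c(O)c2C)cc1`, reaches 16.4%, while compound 2, `Cc1c(OCCCCOc2ccccc2C(=O)O)ccc(C(=O)CC(C)C)c1C`, reaches 76.2%, the higher of the two numbers and a gap that lies beyond the usual scatter of this assay. Compound 3, `COC(=O)c1ccc(OCCCCOc2ccc(C(=O)CC(C)C)c(C)c2C)cc1`, has not yet been measured. It is built from compound 2 by one change: 4-(methoxycarbonyl)phenyl in place of 2-carboxyphenyl on an oxygen on a saturated carbon. The group that enters is the same aryl cap that compound 1 carries, although compound 1 and compound 3 also differ elsewhere, so the low number of compound 1 cannot be tied to that cap alone. For the step from compound 2 to compound 3 a decrease of moderate size is expected, a number 36.2 percentage points lower from compound 2 to compound 3 (beyond the scatter), on the grounds that compound 1 gives 16.4%. In this assay compound 3 is therefore estimated to reach 40%, with a likely range from 15% to 70%.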

Compound 3, largest response reached (reported as percent of maximum), in percent of the reference or control that the assay uses: 15.9%
For compound 3 the middle estimate is 24.1 percentage points above the measured one; measured number inside the range.
By their numbers in this assay, from the lowest: compounds 3 and 1 (each within the scatter of the next); then compound 2.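

In this assay, the swap of the aryl cap on its own gives a number 60.3 percentage points lower from compound 2 to compound 3 (beyond the scatter), so this cap position clearly matters for the maximal response, and 2-carboxyphenyl does far better here than 4-(methoxycarbonyl)phenyl. Methyl in place of hydroxy on an aromatic carbon gives a number 0.5 percentage points lower from compound 1 to compound 3 (within the scatter), so with the 4-(methoxycarbonyl)phenyl cap in place, this second change shows no readable effect. No measurement shown offers an explanation for the large drop on changing the cap.

The two caps differ both in the group they carry and in its place on the ring, and the compounds shown cannot separate these two changes. A 4-carboxyphenyl cap and a 2-(methoxycarbonyl)phenyl cap would each test one change at a time.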